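Swapping the Aryl Group on the Urea Nitrogen

This account rests on a few compounds, and the source may have more. Where it says the series, first, only, none or still open, it means among the compounds named here.

Of the compounds shown here, three built on one shared core have been tested in a functional assay on K562 cells (Homo sapiens) for inhibition, read by sulforhodamine B assay, with a stated time of 48 h, tested at 10 uM; on this read-out lower numbers stand for a stronger effect and higher numbers for a weaker effect at the one concentration tested. Compound 1 `COc1cc2cc(Oc3ccc(NC(=O)Nc4ccccc4)cc3)c(C)nc2cc1OC` gives 42.8%. Compound 2 `COc1cc2cc(Oc3ccc(NC(=O)Nc4ccc(C)cc4)cc3)c(C)nc2cc1OC` gives 90.8%, the highest of the three numbers and so the weakest effect. Compound 3 `COc1cc2cc(Oc3ccc(NC(=O)Nc4cccc(C(F)(F)F)c4)cc3)c(C)nc2cc1OC` gives 11.5%. Compound 4 `COc1cc2cc(Oc3ccc(NC(=O)Nc4ccc(Cl)c(Cl)c4)cc3)c(C)nc2cc1OC` is not yet measured; it differs from compound 2 by 3,4-dichlorophenyl in place of 4-methylphenyl on an amide-type nitrogen. The step that bears most directly on this change is a number 79.3 percentage points lower from compound 2 to compound 3 (beyond the scatter), where another group replaced the same 4-methylphenyl on that nitrogen. Further, a number 48 percentage points higher from compound 1 to compound 2 (beyond the scatter) shows the methyl entering with a large rise. A large fall is therefore expected, a number 68.8 percentage points lower from compound 2 to compound 4 (beyond the scatter). Compound 4 is estimated at 22%, with a range from 5% to 55%.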

Compound 4, a percentage reported as activity, at one concentration (the size of the read-out at that concentration, not a potency): 12.7%
Compound 4: the middle estimate sits 9.3 percentage points above what was measured; measured number inside the range.
By their numbers in this assay, from the lowest: compounds 3 and 4 (each within the scatter of the next); then compound 1; then compound 2.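

Placing 3,4-dichlorophenyl on this nitrogen gives a number 78.1 percentage points lower from compound 2 to compound 4 (beyond the scatter) and a number 30.1 percentage points lower from compound 1 to compound 4 (beyond the scatter), so a second substituted phenyl group, after the 3-(trifluoromethyl)phenyl of compound 3, shows a stronger effect than plain phenyl. Exchanging these two groups gives a number 1.2 percentage points higher from compound 3 to compound 4 (within the scatter), so this assay cannot separate them. Compound 2, with its 4-methylphenyl, goes against any rule that substituting this phenyl ring strengthens the effect. No measurement shown explains these differences. Still open, from the compounds shown here alone, is how 4-chlorophenyl, 3-chlorophenyl or a phenyl ring carrying an amine or a carboxylic acid would behave.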